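The source may report more compounds than this note shows. Statements on the series, on what has been measured and on what is new or still open speak of the compounds shown alone.

Compound 1 `CCCn1c(=O)c2nc(-c3cnn(Cc4cccc(C)c4)c3)[nH]c2n(CCC)c1=O`: 36 nM in an in vitro assay on HEK293 cells for displacement of a labelled ligand from adenosine receptor A2b (Homo sapiens); on this read-out higher numbers stand for weaker inhibition and lower numbers for stronger inhibition
Compound 2 `CCCn1c(=O)c2nc(-c3cnn(Cc4ccccc4C(F)(F)F)c3)[nH]c2n(CCC)c1=O`: 37 nM in this assay
Compound 3 `CCCn1c(=O)c2nc(-c3cnn(Cc4cc(F)ccc4Cl)c3)[nH]c2n(CCC)c1=O`: 4800 nM in this assay

Compound 3 stands highest of the three numbers, set apart by a 130-fold higher number from compound 1 to compound 3 (2.12 log units; beyond the scatter) and by a 130-fold higher number from compound 2 to compound 3 (2.11 log units; beyond the scatter), while a 1.0-fold higher number from compound 1 to compound 2 (0.01 log units; within the scatter) is within the scatter. Compound 4 `CCCn1c(=O)c2nc(-c3cnn(Cc4ccccc4C)c3)[nH]c2n(CCC)c1=O` is not yet measured. The change is 2-methylphenyl in place of 2-chloro-5-fluorophenyl on a saturated chain carbon bound to an aromatic nitrogen. The two large steps onto compound 3 both came from an aryl group carrying a single methyl or trifluoromethyl, so compound 4, which carries a single methyl again, is expected to move most of the way back, with an estimated 110-fold lower number from compound 3 to compound 4 (2.03 log units; beyond the scatter) in this assay. The estimate for compound 4 is 45 nM, with a range from 15 nM to 200 nM.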

Compound 4, inhibition constant: 33 nM
Estimate against measurement, compound 4: 1.4-fold (0.13 log units) above; the range from low to high includes it.
By their numbers in this assay, from the lowest: compounds 4, 1 and 2 (each within the scatter of the next); then compound 3.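

The position tolerates moving the methyl, since 2-methylphenyl and 3-methylphenyl read alike (a 1.1-fold lower number from compound 1 to compound 4 (0.04 log units; within the scatter)), and it tolerates trifluoromethyl in place of methyl on the aromatic carbon (a 1.1-fold lower number from compound 2 to compound 4 (0.05 log units; within the scatter)). Among these four compounds, only 2-chloro-5-fluorophenyl stands apart (a 150-fold lower number from compound 3 to compound 4 (2.16 log units; beyond the scatter)), so the large loss belongs to that group and not to every substituted benzyl. No measurement shown explains this gap.

Going by these compounds, it remains open whether the chlorine, the fluorine or the pair carries the loss. A 2-chlorophenyl group would start to separate these.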